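The source may hold more compounds than are shown below. What is called first, only, known or untested is meant among the compounds shown, and "the series" means these compounds.

Compound 1 `CCCCC[Se]c1nc([Se]CCCCC)c2ccccc2n1` was examined in a functional assay on MCF7 cells (Homo sapiens) for cytotoxicity, read by MTT assay, with a stated time of 72 h; on this read-out higher numbers stand for lower toxicity in this test and lower numbers for higher toxicity in this test. In this test compound 1 gives > 100000 nM, which is a limit of the assay rather than a number. Compound 2 `CSc1nc(NCCCCCO)c2cccnc2n1` in this assay likewise gives > 100000 nM, again a limit and not a number. Both values shown sit at the same limit, as the limit of > 100000 nM in this assay, at which 2 of the 2 values shown sit, records, so compound 1 cannot be ranked against any other compound on these numbers. Compound 3 `CCCCC[Se]c1nc(N)c2ccccc2n1` has not yet been measured in this assay. It differs from compound 1 by one nitrogen atom in place of a group of 6 heavy atoms (5 carbon, 1 selenium; no ring), on an aromatic carbon. For the measured compounds named here, with no measured step to rest on, the change is expected to shift the value by no more than the scatter, giving an expected step of a number no higher from compound 1 to compound 3 (the limit leaves the size open), with a fair chance that the assay again reports only a limit. Compound 3 is therefore estimated at 100000 nM, within 30000 nM to 300000 nM.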

Compound 3, concentration lethal to 50% of the cells: 90400 nM
For compound 3 the middle estimate is 1.1-fold (0.04 log units) above the measured one; low and high end bracket the measured number.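

In this assay, putting amino in place of the group of 6 heavy atoms on the aromatic carbon gives an at least 1.1-fold lower number from compound 1 to compound 3 (0.04 log units; that floor lies within the scatter). This change yields the first value shown that is a number and not a limit, with compound 3 at 90400 nM, so this position now has a measured reference point. The true size of the step stays unknown because the starting value is a limit of the assay and not a number: the limit of > 100000 nM in this assay, at which 2 of the 3 values shown sit.

Since only one change at this aromatic carbon is shown, the compounds leave open whether a methylamino group, a hydroxyl or a carboxylic acid there would also give a number. They also leave open how a longer chain on the remaining selenium would read in this assay with amino kept in place.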